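From Methoxyphenyl to Nitrophenyl on the Shared Core

The compounds below may be only part of what the source reports. "The series", "measured", "known", "first", "only" and "open" are said of these compounds alone.

Measured compounds:
compound 1 `Cc1cccc(-n2nncc2CN2C(=O)C3(C(C#N)=C(N)Oc4c3c3nc5ccccc5nc3c3ccccc43)c3ccccc32)c1`: > 50000 nM
compound 2 `COc1ccccc1-n1nncc1CN1C(=O)C2(C(C#N)=C(N)Oc3c2c2nc4ccccc4nc2c2ccccc32)c2ccccc21`: > 50000 nM

In a functional assay on HepG2 cells (Homo sapiens) for antiproliferative activity, read by MTT assay, with a stated time of 48 h (on this read-out lower numbers stand for stronger inhibition and higher numbers for weaker inhibition), compound 1 gives > 50000 nM, which is a limit of the assay rather than a number. Compound 2 gives > 50000 nM, also a limit. Both values therefore sit at the limit of > 50000 nM in this assay, at which 2 of the 2 values shown sit, and the change from compound 1 to compound 2, 2-methoxyphenyl in place of 3-methylphenyl on an aromatic nitrogen, yields a step that the two limits leave unreadable from compound 1 to compound 2. Compound 2 thus stands at a limit only, with no number to place it against its neighbour.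

Compound 3 `N#CC1=C(N)Oc2c(c3nc4ccccc4nc3c3ccccc23)C12C(=O)N(Cc1cnnn1-c1ccc([N+](=O)[O-])cc1)c1ccccc12` differs from compound 2 by 4-nitrophenyl in place of 2-methoxyphenyl on an aromatic nitrogen. Among the measured compounds shown here, the only measured step that touches this position is a step that the two limits leave unreadable from compound 1 to compound 2, and its size cannot be read. For the measured compounds named here, no measured step bears readably on the move to 4-nitrophenyl, so no direction or size beyond the scatter can be drawn from the data. On that basis compound 3 is expected to remain at the limit as well, with an estimate of 60000 nM (range 20000 nM to 200000 nM), which means an expected step that the limit leaves unreadable from compound 2 to compound 3 in this assay.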

Compound 3, half-maximal inhibitory concentration: > 50000 nM
Compound 3 ended at the assay's limit; the forecaster's own chance of this, stated with the estimate: 80%; the middle value does not contradict the limit.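

In this assay compound 3 gives > 50000 nM as a limit of the assay and not a number. Among the compounds shown here, with compound 1 and compound 2 at the same limit, no step among the three compounds can be read. The compounds shown leave open whether any group on that aromatic nitrogen of the shared core gives a readable value in this assay at all.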